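Azido in place of phenylsulfanyl on a nucleoside chain

The compounds below may be only part of what the source reports. "The series", "measured", "known", "first", "only" and "open" are said of these compounds alone.

The study measures compounds in a functional assay on the whole organism (B cells) with Mus musculus as the target; a higher number here means a larger maximal response, a lower number a smaller maximal response. Compound 1 `C=CCn1/c(=N\C#N)n([C@H]2OC(CO)[C@@H](O)[C@H]2O)c2cc(N)nc(O)c21` gives 85%. Compound 2 `Nc1nc(O)c2c(n1)n(C1OC(CO)[C@@H](O)[C@H]1O)c(=O)n2CC(O)CSc1ccccc1` gives 12%, the lowest of the three values recorded. Compound 3 `Nc1nc(O)c2c(n1)n(C1OC(CO)[C@@H](O)[C@H]1O)c(=O)n2CC(O)CN1CCN(c2ccc(F)cc2)CC1` gives 16%, which lies within the scatter of the value of compound 2, while the value of compound 1 lies well beyond it. No two of these compounds differ in only one place, so their numbers are compared only as they stand.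

Compound 4 `[N-]=[N+]=NCC(O)Cn1c(=O)n(C2OC(CO)[C@@H](O)[C@H]2O)c2nc(N)nc(O)c21` has not yet been measured. It differs from compound 2 as follows: azido in place of phenylsulfanyl on a saturated chain carbon, two bonds along the chain from an oxygen on a saturated carbon. The two compounds that carry a hydroxylated chain on the shared core, compound 2 and compound 3, both give small maximal responses, and the change to azido keeps the chain and its hydroxyl intact. The step from compound 2 to compound 4 is therefore expected to be small, a number 3 percentage points higher from compound 2 to compound 4 (within the scatter), with no direction beyond the scatter. Compound 4 is estimated at 15%, within 4% to 35%.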

Compound 4, largest response reached (reported as maximal response), in percent of the reference or control that the assay uses: 91%
Estimate against measurement, compound 4: 76 percentage points below; measured number outside the range, above it.
By their numbers in this assay, from the lowest: compounds 2 and 3 (each within the scatter of the next); then compounds 1 and 4 (each within the scatter of the next).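

In this assay, azido in place of phenylsulfanyl on a saturated chain carbon, two bonds along the chain from an oxygen on a saturated carbon, gives a number 79 percentage points higher from compound 2 to compound 4 (beyond the scatter). Among these compounds, this is the first comparison in which only one place changes, and it shows that the hydroxylated chain on the shared core does not by itself keep the maximal response small: compound 4 carries that chain and still reaches 91%. Nothing available here accounts for the size of this step.

From the compounds shown here alone, it remains open whether the high response depends on azido itself or follows from the loss of the phenylsulfanyl group and its aromatic ring. A primary amine or a methylsulfanyl group on the same carbon would help to separate those two readings.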